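Fluorobenzyl thioether variant of compound 2

A few compounds are considered here, and "the series" means these few. Any claim that something is new, unique, unknown or untested is made for them only; others in the source may bear on it.

Compound 2 `CCSc1n[nH]c(-n2[se]c3ccccc3c2=O)n1` gives 14100 nM in a functional assay on HeLa cells (Homo sapiens) for antiproliferative activity, read by CCK-8 assay, with a stated time of 48 h (on this read-out lower numbers stand for stronger inhibition and higher numbers for weaker inhibition), the lowest of the two numbers shown; compound 3 `CCCCCCSc1n[nH]c(-n2[se]c3ccccc3c2=O)n1` gives 35900 nM in this assay. Compound 1 `O=c1c2ccccc2[se]n1-c1nc(SCc2ccccc2)n[nH]1` returns only a limit, > 50000 nM, in this assay. Compound 4 `O=c1c2ccccc2[se]n1-c1nc(SCc2ccc(F)cc2)n[nH]1` carries the change (4-fluorophenyl in place of methyl on a saturated chain carbon bound to a sulfur). The measured step that bears on it runs the other way: an at least 3.5-fold lower number from compound 1 to compound 2 (0.54 log units; beyond the scatter), and the limit at the limit of > 50000 nM in this assay, at which 1 of the 3 values shown sits, leaves its true size open. Alongside, an at least 1.3-fold lower number from compound 1 to compound 3 (0.14 log units; that floor lies within the scatter) and a 2.5-fold higher number from compound 2 to compound 3 (0.41 log units; beyond the scatter) show that the other groups on a saturated chain carbon bound to a sulfur gave higher numbers than compound 2. A step of a 4.3-fold higher number from compound 2 to compound 4 (0.63 log units; beyond the scatter) toward higher numbers is therefore expected, possibly reaching the limit. Compound 4 is estimated at 60000 nM, between 20000 nM and 180000 nM.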

Compound 4, half-maximal inhibitory concentration: > 50000 nM
Compound 4 was reported as a limit; the forecaster's own chance of this, stated with the estimate: 60%; the middle value is on the limit's open side.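

In this assay, 4-fluorophenyl on a saturated chain carbon bound to a sulfur does not hold the level seen with methyl, and the step is an at least 3.5-fold higher number from compound 2 to compound 4 (0.54 log units; beyond the scatter) here. Against pentyl the reading is an at least 1.3-fold higher number from compound 3 to compound 4 (0.14 log units; that floor lies within the scatter) and fixes no order between these two groups. The step for fluoro in place of hydrogen on an aromatic carbon cannot be read, because compound 1 and compound 4 both stand at a limit of the assay: the limit of > 50000 nM in this assay, at which 2 of the 4 values shown sit.

On these data alone, whether a propyl chain would fall below compound 2 remains open. So does the effect of a terminal amine or carboxylic acid on the chain.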